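This account rests on a few compounds, and the source may have more. Where it says the series, first, only, none or still open, it means among the compounds named here.

Of the compounds shown here, two built on a shared core have so far been measured in a functional assay on HCT-116 cells (Homo sapiens) for inhibition, read by MTT assay, with a stated time of 48 h; a lower number here means a stronger inhibitor, a higher number a weaker inhibitor. Compound 1 `Brc1ccc(CSc2nnc(-c3ccncc3)n2-c2ccccc2)cc1` carries a 4-bromophenyl group on a saturated chain carbon bound to a sulfur, and in this assay compound 1 gives 11100 nM. Compound 2 `Fc1cccc(F)c1CSc1nnc(-c2ccncc2)n1-c1ccccc1` carries a 2,6-difluorophenyl group at that same place, and in this assay compound 2 gives 22100 nM. Where compound 2 stands is simple to tell: its only neighbour is compound 1, and the step between them is a 2.0-fold higher number from compound 1 to compound 2 (0.30 log units; within the scatter), so on these numbers the two compounds cannot be told apart.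

Compound 3 `O=[N+]([O-])c1ccc(CSc2nnc(-c3ccncc3)n2-c2ccccc2)cc1` has not yet been measured. It differs from compound 2 at the same place: 4-nitrophenyl in place of 2,6-difluorophenyl on a saturated chain carbon bound to a sulfur. Going by the values given here, the only measured step that bears on this change is the exchange of one aryl group for another at this carbon, from compound 1 to compound 2, which stayed within the scatter. On that basis no step beyond the scatter is expected in this assay when going from compound 2 to compound 3. The estimate for compound 3 is therefore 16000 nM, with a range from 5000 nM to 50000 nM, which amounts to an expected step of a 1.4-fold lower number from compound 2 to compound 3 (0.14 log units; within the scatter).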

Compound 3, half-maximal inhibitory concentration: 23800 nM
The estimate for compound 3 lay 1.5-fold (0.17 log units) below the measured number, and the stated range covers the measured number.
By their numbers in this assay, from the lowest: compounds 1, 2 and 3 (each within the scatter of the next, the first and the last beyond it).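

In this assay the exchange on the saturated chain carbon bound to a sulfur gives a 1.1-fold higher number from compound 2 to compound 3 (0.03 log units; within the scatter) and so 4-nitrophenyl and 2,6-difluorophenyl cannot be told apart at this position, although the two groups differ in their substituents and only 4-nitrophenyl carries hydrogen-bond acceptors. Going by these compounds alone, replacing bromo with nitro on an aromatic carbon gives a 2.1-fold higher number from compound 1 to compound 3 (0.33 log units; beyond the scatter) and this is the first step to pass beyond the scatter, yet it remains modest, and compound 2 stays within the scatter of both of the other compounds. No measurement is available here that could explain these numbers.

As far as these compounds go, all three compounds keep a substituted phenyl group on this carbon, so it remains open how the shared core would respond to an amine, a carboxylic acid or a longer chain in that place. From the compounds shown here alone, it also remains open whether the small gap between bromo and nitro would persist with another group on the same aromatic carbon, such as methoxy or nitrile.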